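Replacing Chloro with Nitro in Compound 3

The source may hold more compounds than are shown below. What is called first, only, known or untested is meant among the compounds shown, and "the series" means these compounds.

For the measured compounds named here, in a functional assay on MCF7 cells (Homo sapiens) for cytotoxicity, read by MTT assay, with a stated time of 96 h (on this read-out lower numbers stand for stronger inhibition and higher numbers for weaker inhibition), compound 3 (`COc1cc(C(=O)c2cn(-c3cccc(C)c3)cc2-c2ccccc2Cl)cc(OC)c1OC`) gives 420 nM, the highest of the three numbers measured so far. Compound 2 (`COc1cc(C(=O)c2cn(-c3cccc(C)c3)cc2-c2ccccc2F)cc(OC)c1OC`) gives 190 nM, and compound 1 (`COc1cc(C(=O)c2cn(-c3ccccc3)cc2-c2ccccc2[N+](=O)[O-])cc(OC)c1OC`) gives 49 nM. The next structure, compound 4 (`COc1cc(C(=O)c2cn(-c3cccc(C)c3)cc2-c2ccccc2[N+](=O)[O-])cc(OC)c1OC`), follows from compound 3 through a single change: nitro in place of chloro on an aromatic carbon. This is nitro in place of chloro on an aromatic carbon, ortho to a large group, or 2-chlorophenyl to 2-nitrophenyl.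

Going by the values given here, only one measured step concerns this place: a 2.2-fold higher number from compound 2 to compound 3 (0.34 log units; beyond the scatter), with chloro in place of fluoro. That step is modest but beyond the scatter, and it does not involve nitro. Among the compounds with values here, the only measured compound with the 2-nitrophenyl group is compound 1 at 49 nM, the lowest of the three numbers. Within the data shown here, compound 1 has no measured one-place step to any other compound, so it offers only an indirect guide. On that limited evidence, a moderate move towards a lower number is expected in this assay, and the estimated step is a 3.2-fold lower number from compound 3 to compound 4 (0.51 log units; beyond the scatter). The uncertainty remains wide. For compound 4, the estimated value is 130 nM, with an expected range of 40 nM to 400 nM.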

Compound 4, half-maximal inhibitory concentration: 220 nM
The estimate for compound 4 lay 1.7-fold (0.23 log units) below the measured number, and the stated range covers the measured number.
By their numbers in this assay, from the lowest: compound 1; then compounds 2, 4 and 3 (each within the scatter of the next, the first and the last beyond it).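

In this assay, the change from 2-chlorophenyl to 2-nitrophenyl gives a 1.9-fold lower number from compound 3 to compound 4 (0.28 log units; within the scatter) and the change from fluoro to nitro gives a 1.2-fold higher number from compound 2 to compound 4 (0.06 log units; within the scatter), so nitro at this place, ortho to a large group, cannot be told apart from either halogen, although the two halogens do differ by a 2.2-fold higher number from compound 2 to compound 3 (0.34 log units; beyond the scatter). For the compounds shown here, the low number of compound 1 therefore cannot be credited to the nitro group alone: with nitro held fixed, methyl in place of hydrogen on an aromatic carbon gives a 4.5-fold higher number from compound 1 to compound 4 (0.65 log units; beyond the scatter), which is the only new step beyond the scatter and shifts attention from the changed group to this second place on the molecule. Nothing available on these compounds accounts for either the flat result at the nitro position or the step tied to the methyl.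

The compounds shown leave open whether methyl in place of hydrogen gives a step of similar size when fluoro or chloro occupies the place taken by nitro in compound 4. They also leave open how an amine or a carboxylic acid at this same aromatic carbon would read in this assay.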